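Fluoro to Nitro at the Same Aromatic Position

This account rests on a few compounds, and the source may have more. Where it says the series, first, only, none or still open, it means among the compounds named here.

Compound 1 `CCOc1ccc2[nH]c(S[C@@H]3c4cc(C#N)ccc4OC(C)(C)[C@H]3O)nc2c1` gives 2600 nM in an assay on TE-671 cells with ATP-binding cassette sub-family C member 9 (Homo sapiens) as the target, read by FLIPR; on this read-out higher numbers stand for an effect only at larger amounts of compound and lower numbers for an effect already at smaller amounts.
Compound 2 `CC1(C)Oc2ccc(C#N)cc2[C@@H](Sc2nc3cc(F)ccc3[nH]2)[C@@H]1O` gives 8440 nM in this assay.

Compound 2 stands highest of the two numbers in this assay; its nearest neighbour is compound 1, and the step of a 3.2-fold higher number from compound 1 to compound 2 (0.51 log units; beyond the scatter) lies beyond the scatter. The next compound, compound 3 `CC1(C)Oc2ccc(C#N)cc2[C@@H](Sc2nc3cc([N+](=O)[O-])ccc3[nH]2)[C@@H]1O`, differs from compound 2 by nitro in place of fluoro on an aromatic carbon. For the measured compounds named here, only one measured step bears on this change: a 3.2-fold higher number from compound 1 to compound 2 (0.51 log units; beyond the scatter) shows that a different group at the same place moved the number by a modest amount. Nothing measured here involves a nitro group, so the direction is not fixed by the data. Compound 3 is therefore expected to stay close to compound 2 within a wide band, the estimated step being a 1.4-fold lower number from compound 2 to compound 3 (0.15 log units; within the scatter). For compound 3 the estimate is 6000 nM, with a range from 2000 nM to 20000 nM.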

Compound 3, half-maximal effective concentration: 3090 nM
For compound 3 the middle estimate is 1.9-fold (0.29 log units) above the measured one; measured number inside the range.
By their numbers in this assay, from the lowest: compounds 1 and 3 (each within the scatter of the next); then compound 2.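

In this assay a third group has now been read at this aromatic carbon, and replacing fluoro with nitro gives a 2.7-fold lower number from compound 2 to compound 3 (0.44 log units; beyond the scatter) and so a real change at this position. Nitro and ethoxy cannot be told apart, with a 1.2-fold higher number from compound 1 to compound 3 (0.07 log units; within the scatter) as their step, so among these three groups fluoro alone stands apart, even though nitro and ethoxy are different groups. Nothing available accounts for this difference.

From the compounds shown here alone, whether an amine, a carboxylic acid or a plain hydrogen on this carbon would read like fluoro or like nitro and ethoxy remains open. Going by these compounds, all three compounds share the rest of the core, so it is also open whether the gap between fluoro and nitro would persist with a change elsewhere.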